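The compounds below may be only part of what the source reports. "The series", "measured", "known", "first", "only" and "open" are said of these compounds alone.

Compound 1 `CN(C(=O)CNC(=O)CN)c1ccc(Cl)cc1C(=O)c1ccccc1Cl`: 27.7 mg/kg
Compound 2 `CC(=O)NCC(=O)Nc1ccc(Cl)cc1C(=O)c1ccccc1`: > 100 mg/kg
Compound 3 `CN(C(=O)CNC(=O)c1ccccc1)c1ccc(Cl)cc1C(=O)c1ccccc1`: > 100 mg/kg

In a functional assay on the whole organism with Mus musculus as the target, in the rotarod test (on this read-out higher numbers stand for an effect only at larger amounts of compound and lower numbers for an effect already at smaller amounts), compound 1 gives 27.7 mg/kg. Among the measured compounds shown here, this is the only number among the three measured compounds. For compound 2 the result is not a number but a limit of the assay, > 100 mg/kg. For compound 3 the result is likewise a limit, > 100 mg/kg. Compound 1 therefore stands apart from the other two, which both sit at the limit of > 100 mg/kg in this assay, at which 2 of the 3 values shown sit.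

Compound 4 `CN(C(=O)CNC(=O)CN1CCN(c2ccccc2)CC1)c1ccc(Cl)cc1C(=O)c1ccccc1Cl` has not yet been measured in this assay. It differs from compound 1 in one place: 4-phenylpiperazin-1-yl in place of amino on a saturated chain carbon bound to a carbonyl carbon. For the measured compounds named here, no pair of measured compounds differs in just one place, so no measured step can be used to judge the size of this change. The expectation must rest on compound 1 alone, which gives 27.7 mg/kg in this assay. A step of moderate size is expected, a 1.6-fold higher number from compound 1 to compound 4 (0.21 log units; within the scatter), with the direction uncertain. Compound 4 is estimated at 45 mg/kg, within a range from 12 mg/kg to 100 mg/kg.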

Compound 4, dose for half-maximal effect: > 100 mg/kg
Compound 4 ended at the assay's limit (the forecaster's own chance of this, stated with the estimate: 35%); middle value at least 2.2-fold (0.34 log units) away from the limit.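

In this assay, among the compounds shown here, this is the first step that can be read, and it shows that the saturated chain carbon bound to a carbonyl carbon is sensitive to what it carries: 4-phenylpiperazin-1-yl in place of amino gives an at least 3.6-fold higher number from compound 1 to compound 4 (0.55 log units; beyond the scatter). The change swaps a group of 1 heavy atom for one of 12 heavy atoms with two rings, and this large group does not retain the effect at the smaller amounts seen with amino. The result for compound 4 is a limit and not a number, so the true size of the step stays unknown: the limit of > 100 mg/kg in this assay, at which 3 of the 4 values shown sit.

Going by these compounds, with only this one replacement to compare, it remains open whether the piperazine ring or the phenyl ring on it matters more. A dimethylamino group or an unsubstituted piperazin-1-yl at this place could help to separate the two.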